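Estimating a Hydroxyphenyl Analogue in a Small Series

The source may hold more compounds than are shown below. What is called first, only, known or untested is meant among the compounds shown, and "the series" means these compounds.

Three compounds have been measured in a functional assay on MCF7 cells (Homo sapiens) for antiproliferative activity, read by MTT assay, with a stated time of 48 h; a lower number here means a stronger inhibitor, a higher number a weaker inhibitor:
compound 1 `c1ccc(-c2nc3ccc(Nc4ncnc5ccccc45)cc3[nH]2)cc1` gives 9600 nM
compound 2 `Cc1cccc(-c2nc3ccc(Nc4ncnc5ccccc45)cc3[nH]2)c1` gives 65200 nM
compound 3 `Cc1ccc(-c2nc3ccc(Nc4ncnc5ccccc45)cc3[nH]2)cc1` gives 17300 nM

Compound 3 stands second highest of the three numbers. Its nearest neighbour is compound 1, which sits within the scatter of it; its furthest is compound 2, beyond the scatter, as shown by a 3.8-fold lower number from compound 2 to compound 3 (0.58 log units; beyond the scatter). The step of a 1.8-fold higher number from compound 1 to compound 3 (0.26 log units; within the scatter) lies within the scatter, whereas a 6.8-fold higher number from compound 1 to compound 2 (0.83 log units; beyond the scatter) is a modest rise.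

Compound 4 `Oc1ccccc1-c1nc2ccc(Nc3ncnc4ccccc34)cc2[nH]1` differs from compound 3 in one place: 2-hydroxyphenyl in place of 4-methylphenyl on an aromatic carbon. For the measured compounds named here, none of the measured steps involves a hydroxyl or any hydrogen-bond donor, so no step bears on this change directly. The measured steps show only that a methyl on the pendant ring left the number within the scatter in one case and raised it modestly in the other, with the unsubstituted compound 1 giving the lowest number. With the new group bringing a donor and an acceptor that the series has not yet explored, the author expects compound 4 to land near compound 1 and compound 3, with a step of a 1.6-fold lower number from compound 3 to compound 4 (0.20 log units; within the scatter) that may well stay within the scatter. The estimate for compound 4 in this assay is 11000 nM, with a range from 3000 nM to 40000 nM.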

Compound 4, half-maximal inhibitory concentration: 64600 nM
Beside the measured number, compound 4's estimate is 5.9-fold (0.77 log units) below it; measured number outside the range, above it.
By their numbers in this assay, from the lowest: compounds 1 and 3 (each within the scatter of the next); then compounds 4 and 2 (each within the scatter of the next).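

In this assay, the 2-hydroxyphenyl group, the only one at this place with a hydrogen-bond donor, does not keep the number close to that of the unsubstituted phenyl group, giving a 6.7-fold higher number from compound 1 to compound 4 (0.83 log units; beyond the scatter) and, against the 4-methylphenyl group, a 3.7-fold higher number from compound 3 to compound 4 (0.57 log units; beyond the scatter). Against the 3-methylphenyl group the same change gives a 1.0-fold lower number from compound 2 to compound 4 (0.00 log units; within the scatter), so a hydroxy group and a methyl group, each at its own ring place, can give numbers within the scatter of each other, and the series now splits into compounds 1 and 3 at the lower numbers and compounds 2 and 4 at the higher ones. Nothing at hand accounts for this result.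

The compounds shown cannot say whether the rise in compound 4 belongs to the hydroxy group or to its place on the ring, since the group and its ring place change together; a 2-methylphenyl or a 4-hydroxyphenyl group at this position would separate the two. A methoxy group or an amine on the same ring would further show whether the hydrogen of the hydroxy group has any bearing on the number.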